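Trifluoromethyl for fluoro on the aryl ring in this series

A few compounds are considered here, and "the series" means these few. Any claim that something is new, unique, unknown or untested is made for them only; others in the source may bear on it.

Compound 2 `CC(C)(C)C1=NN(c2cccc(F)c2)C(c2ccc(O)cc2)C1` gives 19.3% in an assay on isolated protein for inhibition of protein kinase C iota type (Homo sapiens), tested at 20 uM (on this read-out lower numbers stand for less inhibition and higher numbers for more inhibition at the one concentration tested (going by the name of the read-out)), the lowest of the two numbers in hand; compound 1 `CC(C)(C)C1=NN(c2cccc(Cl)c2)C(c2ccc(O)cc2)C1` gives 43.5%. Going by the values given here, the one step that bears on the change is a number 24.2 percentage points lower from compound 1 to compound 2 (beyond the scatter). Compound 3 `CC(C)(C)C1=NN(c2cccc(C(F)(F)F)c2)C(c2ccc(O)cc2)C1` differs from compound 2 by trifluoromethyl in place of fluoro on an aromatic carbon. A larger group in place of chloro had not been tried, so only the chloro-to-fluoro step guides the view; as the smaller group lowered the number, the step of a number 18.7 percentage points higher from compound 2 to compound 3 (beyond the scatter) is expected to run upward. Compound 3 is thus estimated at 38%, within 15% to 60%.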

Compound 3, a percentage reported as inhibition, at one concentration (the size of the read-out at that concentration, not a potency): 17%
For compound 3 the middle estimate is 21 percentage points above the measured one, and the stated range covers the measured number.
By their numbers in this assay, from the lowest: compounds 3 and 2 (each within the scatter of the next); then compound 1.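

In this assay, trifluoromethyl does not recover the number seen with chloro: the step to fluoro reads a number 2.3 percentage points lower from compound 2 to compound 3 (within the scatter), and the step from chloro reads a number 26.5 percentage points lower from compound 1 to compound 3 (beyond the scatter). Heavy-atom count at this position therefore does not track the read-out in a simple way, since chloro stands apart from both fluoro and trifluoromethyl among these three compounds. Nothing measured here accounts for the chloro result.

On these data alone, whether bromo or methyl at this position gives a number like that of compound 1 stays open. So does the effect of a methoxy group or an amine there.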